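This account rests on a few compounds, and the source may have more. Where it says the series, first, only, none or still open, it means among the compounds named here.

Compound 2 `CN1Cc2ccc(OCc3cccnc3)cc2[C@@H](O)C1` shares its core with compound 1 `CN1Cc2ccc(OCc3ccccc3)cc2[C@@H](O)C1`; the two differ only in the group on a saturated chain carbon bound to an oxygen on an aromatic ring. In an ADME assay on Vero cells (Chlorocebus sabaeus) for cytotoxicity, read by sulforhodamine B assay, with a stated time of 72 h (on this read-out higher numbers stand for weaker inhibition and lower numbers for stronger inhibition), compound 1 reaches only the assay limit of > 100000 nM. In this assay compound 2 likewise reaches only a limit, > 50000 nM. So compound 2 stands at a limit and not at a number, and the step that the two limits leave unreadable from compound 1 to compound 2 cannot be read, since both values sit at limits (the limit of > 100000 nM in this assay, at which 1 of the 2 values shown sits, and (the limit of > 50000 nM in this assay, at which 1 of the 2 values shown sits)).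

Compound 3 `COCCOCOc1ccc2c(c1)[C@@H](O)CN(C)C2` carries the change (2-methoxyethoxy in place of pyridin-3-yl on a saturated chain carbon bound to an oxygen on an aromatic ring). Among the compounds with values here, the only measured step that bears on this part of the molecule is the one from compound 1 to compound 2, and it is unreadable, so it gives no basis for a step of any size or direction in this assay beyond the scatter. Compound 3 is therefore expected to show 60000 nM, within a range from 20000 nM to 200000 nM. The step that the limit leaves unreadable from compound 2 to compound 3 is expected to be none beyond the scatter.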

Compound 3, half-maximal inhibitory concentration: > 50000 nM
Compound 3: no number, only a limit; the forecaster's own chance of this, stated with the estimate: 80%; the middle value is on the limit's open side.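

Within the data shown here, compound 3 also reaches only a limit in this assay, so no step among compound 1, compound 2 and compound 3 can be read: the limit of > 50000 nM in this assay, at which 2 of the 3 values shown sit. The compounds shown leave open whether phenyl, pyridin-3-yl and 2-methoxyethoxy differ at all on this read-out.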